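A Sulfonyl Swap on the Pyrrolidine Ring

The compounds below may be only part of what the source reports. "The series", "measured", "known", "first", "only" and "open" are said of these compounds alone.

Compound 3, `CNC(=O)CN1CC[C@H](n2c(Nc3ccc(F)cc3)nc3cnc(Nc4ccc(N5CCN(C)CC5)cc4)nc32)C1`, has no result yet in a functional assay on A-431 cells (Homo sapiens) for antiproliferative activity, read by MTT assay, with a stated time of 72 h (a lower number here means a stronger inhibitor, a higher number a weaker inhibitor), where its entry for compound 3 reads "not determined" (no result reported). Compound 2, `CN1CCN(c2ccc(Nc3ncc4nc(Nc5ccc(F)cc5)n(CCNS(=O)(=O)C5CC5)c4n3)cc2)CC1`, is likewise without a result there, the entry for compound 2 reading "not determined" (no result reported). Compound 1, `CN1CCN(c2ccc(Nc3ncc4nc(Nc5ccc(F)cc5)n([C@@H]5CCN(S(=O)(=O)C6CC6)C5)c4n3)cc2)CC1`, reaches only a limit of the assay, giving > 10000 nM in this assay. Compound 4, `CN1CCN(c2ccc(Nc3ncc4nc(Nc5ccc(F)cc5)n([C@H]5CCN(S(=O)(=O)C6CC6)C5)c4n3)cc2)CC1`, is the new member; it differs from compound 3 by cyclopropylsulfonyl in place of (methylcarbamoyl)methyl on an amine nitrogen in a ring. No two of the compounds shown have both been measured, so no measured step exists to lean on, and the only number in view is the limit that compound 1 shows, which is the limit of > 10000 nM in this assay, at which 1 of the 3 values shown sits. The expectation for compound 4 is therefore that it too sits near that limit, with a wide range. Compound 4 is estimated at 10000 nM, between 2000 nM and 50000 nM.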

Compound 4, half-maximal inhibitory concentration: 1670 nM
Beside the measured number, compound 4's estimate is 6.0-fold (0.78 log units) above it, and the stated range ends above it.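

In this assay, changing only the configuration drawn at a saturated ring carbon from R to S gives an at least 5.9-fold lower number from compound 1 to compound 4 (0.77 log units; beyond the scatter). The cyclopropylsulfonyl group on the pyrrolidine ring therefore allows measurable activity in one configuration, a point compound 1 alone could not show. The gap can be assigned to that stereocentre alone because nothing else changes: the fact that compounds 1 and 4 differ only in the configuration as drawn

Within the data shown here, no step to compound 2 or compound 3 can be read. Still open, going by these compounds, is whether methylsulfonyl or a longer alkylsulfonyl chain, on an amine nitrogen in a ring, would keep the value of compound 4.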